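This account rests on a few compounds, and the source may have more. Where it says the series, first, only, none or still open, it means among the compounds named here.

Four related compounds belong to this study. Compound 1 `ClCc1cccc(Cn2cnc3ncnc(Cl)c32)c1` carries one chloro group on its fused core; compound 3 `ClCc1cccc(Cn2cnc3nc(Cl)nc(Cl)c32)c1` carries two. Compound 2 `ClCc1ccc(Cn2cnc3nc(Cl)nc(Cl)c32)cc1` has the same atoms as compound 3 joined differently, and the difference between the two cores is not broken down here. Compound 4 `ClCc1ccc(Cn2cnc3ncnc(Cl)c32)cc1` has not yet been tested.

In a functional assay on TK-10 cells (Homo sapiens) for cytotoxicity, read by sulforhodamine B assay, with a stated time of 48 h (on this read-out lower numbers stand for stronger inhibition of growth and higher numbers for weaker inhibition of growth), compound 2 gives 290 nM, compound 1 gives 3310 nM and compound 3 gives 30200 nM. Compound 2 therefore shows the lowest number of the three measured compounds.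

From compound 3 to compound 1 one change is made: hydrogen in place of chloro on an aromatic carbon. In this assay this brings a 9.1-fold lower number from compound 3 to compound 1 (0.96 log units; beyond the scatter).

From compound 2 to compound 4 the change is hydrogen in place of chloro on an aromatic carbon. Its surroundings, as described, are the same as in the earlier pair, so this is the same change made a second time, from a stronger starting compound. Going by the values given here, only one earlier example of it exists, which is a thin basis for any expectation.

Compound 4 is expected to give a 5.8-fold lower number from compound 2 to compound 4 (0.76 log units; beyond the scatter) in this assay, because the same change gave a 9.1-fold lower number from compound 3 to compound 1 (0.96 log units; beyond the scatter). The estimated value for compound 4 in this assay is 50 nM, with a plausible range from 10 nM to 250 nM.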

Compound 4, concentration for total growth inhibition: 2950 nM
Estimate against measurement, compound 4: 59-fold (1.77 log units) below, and the stated range ends below it.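

Replacing the chloro group with hydrogen at the carbon between two ring nitrogen atoms gives a 10-fold higher number from compound 2 to compound 4 (1.01 log units; beyond the scatter) in this assay, so this change does not carry over from one core to the other in this series. This step and the earlier one run in opposite directions, which shows that the outcome of this single swap depends on the compound that receives it, at least across these two pairs: the same change on two cores in this assay, a 9.1-fold lower number (0.96 log units; beyond the scatter) from compound 3 to compound 1 and a 10-fold higher number (1.01 log units; beyond the scatter) from compound 2 to compound 4, 93-fold (1.97 log units) apart, beyond the scatter of two such steps. What this comparison does not show is why the direction flips, and two pairs are too few to predict what the same swap would do on any further core.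

The compounds shown leave open what an amine or a methoxy group would do on that same ring carbon in place of chloro or hydrogen, and whether the two cores would again part ways with such groups. Also open, on these data alone, is whether the opposite steps would persist with a plain methyl group in place of the chloromethyl group that all four compounds share.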